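A Bromophenyl Swap on Compound 1

The compounds below may be only part of what the source reports. "The series", "measured", "known", "first", "only" and "open" are said of these compounds alone.

Measured so far in a physicochemical assay for lipophilicity, measured as octanol-water partition (on this read-out higher numbers stand for higher lipophilicity and lower numbers for lower lipophilicity), are three compounds:
- compound 1 `C/C(=N\NC(=O)COc1cccc2ccccc12)c1cccc([N+](=O)[O-])c1` gives 3.37 here
- compound 2 `O=C(COc1cccc2ccccc12)N/N=C/c1ccccc1Br` gives 4.81 here
- compound 3 `COc1ccc(/C=N/NC(=O)COc2cccc3ccccc23)cc1O` gives 3.48 here

Compound 1 has the lowest number of the three, but it cannot be separated from compound 3, since their two values lie within the usual scatter. Compound 2 stands higher than compound 1, and that gap is well beyond the scatter.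

The next compound to be measured is compound 4 `C/C(=N\NC(=O)COc1cccc2ccccc12)c1ccccc1Br`, which has 2-bromophenyl in place of 3-nitrophenyl on a carbon with a double bond to nitrogen. Within the data shown here, no pair of measured compounds differs in one place only, so no direct precedent exists for this swap. The nearest guide is compound 2 (4.81), which also carries 2-bromophenyl, although this single comparison is weak support.

A rise well beyond the scatter is therefore expected, with compound 4 landing near compound 2. The expected change is a number 1.38 log units higher from compound 1 to compound 4 (beyond the scatter) in size. In this assay the estimate for compound 4 is 4.75 (expected range 4.25 to 5.25).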

Compound 4, partition coefficient: 4.44
Beside the measured number, compound 4's estimate is 0.31 log units above it; measured number inside the range.
By their numbers in this assay, from the lowest: compounds 1 and 3 (each within the scatter of the next); then compound 4; then compound 2.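

In this assay, the exchange of 3-nitrophenyl for 2-bromophenyl on a carbon with a double bond to nitrogen now has a direct reading, with the rest of the molecule unchanged: a number 1.07 log units higher from compound 1 to compound 4 (beyond the scatter) is a large step. This shows that the read-out responds strongly at this position, since one exchange of an aromatic group, with the shared core kept intact, moves the number well beyond the scatter. Nothing measured accounts for the size of this step, so it stands as an observation about this one pair.

Among these compounds, the single step also cannot separate what is lost with 3-nitrophenyl from what is gained with 2-bromophenyl, since the two groups differ in more than one respect and no third group on this carbon has been compared with them. A plain phenyl ring, or a phenyl ring carrying an amine or a carboxylic acid, at the same place would show whether the step belongs to the bromine, to the nitro group or to both.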